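Swapping the Aryl Group of Compound 2 for Phenylethenyl

The compounds below may be only part of what the source reports. "The series", "measured", "known", "first", "only" and "open" are said of these compounds alone.

Measured in a functional assay on HepG2 cells (Homo sapiens) for inhibition, read by MTT assay, with a stated time of 48 h; a higher number here means a weaker inhibitor, a lower number a stronger inhibitor:
Compound 1 `CS(=O)(=O)c1ccc(-c2nc3ccccn3c2Sc2ccccc2)cc1`: 13200 nM
Compound 2 `Cc1ccc(-c2nc3ccccn3c2Sc2ccccc2)cc1`: 67900 nM
Compound 3 `c1ccc(Sc2c(-c3cccc4ccccc34)nc3ccccn23)cc1`: 9900 nM

Compound 2 has the highest number of the three, which makes it the weakest inhibitor measured so far. Compound 4 `C(=C/c1nc2ccccn2c1Sc1ccccc1)\c1ccccc1` differs from it in one place on the shared core: 2-phenylethenyl in place of 4-methylphenyl on an aromatic carbon. Put simply, 2-phenylethenyl stands in place of 4-methylphenyl on an aromatic carbon.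

Going by the values given here, only one measured step bears on this even indirectly: a 5.1-fold higher number from compound 1 to compound 2 (0.71 log units; beyond the scatter). That step is modest, and it changes a group carried on the aromatic ring rather than replacing the ring as a whole. Compound 3, with another group in the place that changes here, gives 9900 nM, a lower number than compound 2 at 67900 nM. Among the compounds with values here, no measured compound yet carries 2-phenylethenyl, so any forecast is uncertain.

In this assay the expected change is a 2.3-fold lower number from compound 2 to compound 4 (0.35 log units; beyond the scatter), a modest one toward a stronger inhibitor. For compound 4 the estimated value is 30000 nM, with an expected range of 11000 nM to 80000 nM.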

Compound 4, half-maximal inhibitory concentration: 8800 nM
Compound 4: the middle estimate sits 3.4-fold (0.53 log units) above what was measured, outside the stated range (below it).
By their numbers in this assay, from the lowest: compounds 4, 3 and 1 (each within the scatter of the next); then compound 2.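

In this assay, putting 2-phenylethenyl in place of 4-methylphenyl gives a 7.7-fold lower number from compound 2 to compound 4 (0.89 log units; beyond the scatter), so at this aromatic carbon the six-membered ring need not be bonded directly to the shared core: a group with a double bond outside aromatic rings, which holds that ring further out, gives a stronger inhibitor than compound 2. Compound 4 also lies within the scatter of compound 1 and of compound 3, so 2-phenylethenyl does as well here as the groups these two carry at the same place. Nothing in hand explains why this change lowers the number.

Whether the double bond itself matters stays open, since 2-phenylethyl, its saturated counterpart, is not among the compounds shown. On these data alone, the effect of an amine or a carboxylic acid on the ring of 2-phenylethenyl also remains unknown.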